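The source may hold more compounds than are shown below. What is called first, only, known or untested is meant among the compounds shown, and "the series" means these compounds.

Compound 1 `COc1cccc(N2CCN(CC(=O)N3CCN(c4nnc(-c5ccc(Cl)cc5)c(-c5ccc(Cl)cc5)n4)CC3)CC2)c1` gives 202000 nM in an ADME assay on NIH3T3 cells (Mus musculus) for cytotoxicity, read by MTT assay, with a stated time of 24 h; a lower number here means a stronger inhibitor, a higher number a weaker inhibitor. Compound 2 `COc1ccc(N2CCN(CC(=O)N3CCN(c4nnc(-c5ccc(Cl)cc5)c(-c5ccc(Cl)cc5)n4)CC3)CC2)cc1` reaches in this assay only the limit > 809000 nM (the limit of > 809000 nM in this assay, at which 1 of the 2 values shown sits). For the measured compounds named here, the single measured step is an at least 4.0-fold higher number from compound 1 to compound 2 (0.60 log units; beyond the scatter). Compound 3 `O=C(CN1CCN(c2ccc([N+](=O)[O-])cc2)CC1)N1CCN(c2nnc(-c3ccc(Cl)cc3)c(-c3ccc(Cl)cc3)n2)CC1` differs from compound 2 by nitro in place of methoxy on an aromatic carbon. Going by the values given here, no measured step bears on this change, and with compound 2 already at the limit, a shift inside this assay would have to be large to register at all. Compound 3 is expected to remain near the limit, estimated at 800000 nM with a range from 250000 nM to 2500000 nM. The expected step is a number no higher from compound 2 to compound 3 (the limit leaves the size open), within the scatter.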

Compound 3, half-maximal inhibitory concentration: > 789000 nM
Compound 3: no number, only a limit (the forecaster's own chance of this, stated with the estimate: 60%); the middle value does not contradict the limit.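

In this assay compound 3 gives > 789000 nM, a limit and not a number. The 4-nitrophenyl group therefore ends at a limit, as 4-methoxyphenyl does, and the series shows an at least 3.9-fold higher number from compound 1 to compound 3 (0.59 log units; beyond the scatter), so a second group differs from 3-methoxyphenyl in this assay. The step between the 4-methoxyphenyl and 4-nitrophenyl compounds cannot be read, since both values are limits.

Open, as far as these compounds go, is whether a 3-nitrophenyl group would give a measurable number like 3-methoxyphenyl. Also open, from the compounds shown here alone, is whether 4-aminophenyl or 4-carboxyphenyl would stay at a limit.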